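A few compounds are considered here, and "the series" means these few. Any claim that something is new, unique, unknown or untested is made for them only; others in the source may bear on it.

Compound 1 `COc1ccc(-c2cc3cccc(OC)c3nc2O)cc1`: 10000 nM
Compound 2 `COc1ccc(-c2cc3c(OC)cc(OC)cc3n(CC#N)c2=O)cc1`: 10000 nM

Among the measured compounds shown here, only two compounds have been measured so far in a functional assay on PC-3 cells (Homo sapiens) for cytotoxicity, read by colorimetric assay and MTT assay; on this read-out higher numbers stand for weaker inhibition and lower numbers for stronger inhibition. Compound 2 gives 10000 nM, level with compound 1 at 10000 nM, so the two cannot be told apart on this read-out.

The next compound is compound 3 `COC(=O)CCn1c(=O)c(-c2ccc(OC)cc2)cc2c(OC)cc(OC)cc21`, which has not yet been measured. It keeps the core of compound 2 and changes one group: (methoxycarbonyl)methyl in place of cyano on a saturated chain carbon bound to an aromatic nitrogen. In words, (methoxycarbonyl)methyl stands in place of cyano on a saturated chain carbon bound to an aromatic nitrogen. Cut one bond further out, this is cyanomethyl changing to 2-(methoxycarbonyl)ethyl.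

For the measured compounds named here, no pair of measured compounds differs in just one place, so the data give no direct guide to the size of such a change. The best anchor is compound 2 at 10000 nM, and no shift in either direction beyond the scatter is expected in this assay. The expected change is no change at the digits printed from compound 2 to compound 3 (within the scatter). For compound 3 the estimated value is 10000 nM, with an expected range of 4000 nM to 25000 nM.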

Compound 3, half-maximal inhibitory concentration: 10000 nM
Beside the measured number, compound 3's estimate shows no gap at the digits printed; the range from low to high includes it.
By their numbers in this assay, from the lowest: compounds 1, 2 and 3 (each within the scatter of the next).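

In this assay, among the compounds shown here, the first step between two compounds that differ in just one place reads no change at the digits printed from compound 2 to compound 3 (within the scatter) and gives a first look at this position. On the saturated chain carbon bound to an aromatic nitrogen, cyano can give way to (methoxycarbonyl)methyl, with 5 heavy atoms in place of 2, a double bond in place of a triple bond and 2 hydrogen-bond acceptors in place of 1, and the read-out stays within the scatter. No measurement shown here accounts for this result.

It stays open whether any group at this position can move the read-out, as both groups shown on this chain leave the number level. An amine or a carboxylic acid at the end of the chain, or a longer chain, would test this more widely.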